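A few compounds are considered here, and "the series" means these few. Any claim that something is new, unique, unknown or untested is made for them only; others in the source may bear on it.

Going by the values given here, compound 3, `Cc1ccc(N/N=C2\CCC(C)n3c2ncc(C(=O)O)c3=O)cc1`, sits at the high end of the three numbers so far: in a functional assay on the whole organism for inhibition, with Rattus norvegicus as the target (a higher number here means that more compound is needed for the effect, a lower number that less compound is needed), compound 3 gives 1.3 umol/kg. Compound 1, `CC1CC/C(=N\Nc2cccc(Cl)c2)c2ncc(C(=O)O)c(=O)n21`, gives 0.6 umol/kg, and compound 2, `CC1CC/C(=N\Nc2ccc(Cl)cc2)c2ncc(C(=O)O)c(=O)n21`, gives 0.5 umol/kg. Between those two the step is small, a 1.2-fold lower number from compound 1 to compound 2 (0.08 log units; within the scatter), whereas the moves to compound 3 are larger, a 2.2-fold higher number from compound 1 to compound 3 (0.34 log units; beyond the scatter) and a 2.6-fold higher number from compound 2 to compound 3 (0.41 log units; beyond the scatter).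

Compound 4, `CC1CC/C(=N\Nc2ccc(C(=O)O)cc2)c2ncc(C(=O)O)c(=O)n21`, differs from compound 3 in one place: carboxy in place of methyl on an aromatic carbon. Among the compounds with values here, the only measured step that touches that same place on the ring is a 2.6-fold higher number from compound 2 to compound 3 (0.41 log units; beyond the scatter), where methyl replaced chloro and the number rose modestly. Within the data shown here, no measured compound carries a carboxy on that ring, so the three measurements give no direct reading on the new group; they only show that the ring substituent at this place shifts the number by a modest amount in either direction. On that basis a modest step is expected for compound 4, most plausibly towards a higher number, though a smaller shift within the scatter cannot be excluded; the step is estimated as a 1.9-fold higher number from compound 3 to compound 4 (0.28 log units; within the scatter). Compound 4 is therefore expected to give about 2.5 umol/kg in this assay, with a range from 0.8 umol/kg to 8 umol/kg.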

Compound 4, dose for 50% inhibition: 7.6 umol/kg
For compound 4 the middle estimate is 3.0-fold (0.48 log units) below the measured one; the measured number falls inside the stated range.
By their numbers in this assay, from the lowest: compounds 2 and 1 (each within the scatter of the next); then compound 3; then compound 4.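

Going by these compounds alone, at this aromatic carbon, para to a large group, swapping chloro for methyl had moved the number only modestly, a 2.6-fold higher number from compound 2 to compound 3 (0.41 log units; beyond the scatter), so the earlier compounds showed only a limited range for this place in this assay. Carboxy extends that range well beyond what those two groups showed, with a 5.8-fold higher number from compound 3 to compound 4 (0.77 log units; beyond the scatter) and, against chloro, a 15-fold higher number from compound 2 to compound 4 (1.18 log units; beyond the scatter), the second of these being a large step. The three groups seen at this place thus give rising numbers in the order chloro, methyl, carboxy, so the position is clearly sensitive to what it carries, although nothing available explains why the number rises with carboxy.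

The compounds shown leave open whether the rise belongs to the carboxylic acid itself, since neither its methyl ester, an amide nor an amine appears at this place for comparison. They also leave open whether a carboxy on another carbon of this ring would raise the number to the same extent, and whether a longer chain ending in a carboxylic acid would behave like compound 4.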